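The source may report more compounds than this note shows. Statements on the series, on what has been measured and on what is new or still open speak of the compounds shown alone.

Compound 1, `C/C(=C\c1cc(-c2ccc(C)cc2)co1)C(N)=O`, gives in a functional assay on BGC-823 cells (Homo sapiens) for cytotoxicity, read by CCK-8 assay, with a stated time of 24 h (a lower number here means a stronger inhibitor, a higher number a weaker inhibitor), a value of > 50000 nM, which is a limit of the assay.
Compound 2, `C/C(=C\c1cc(-c2ccccc2)cs1)C(N)=O`, gives in this assay a value of > 50000 nM, again a limit.
Compound 3, `C/C(=C\c1cc(-c2ccc(C)cc2)cs1)C(N)=O`, gives in this assay a value of > 50000 nM, also a limit.

Compound 3 therefore stands at the limit of > 50000 nM in this assay, at which 3 of the 3 values shown sit, with no numerical value of its own. For the measured compounds named here, the only step among the measured compounds, a step that the two limits leave unreadable from compound 2 to compound 3, is unreadable for the same reason. Compound 4, `C/C(=C\c1cc(-c2ccc(F)cc2)cs1)C(N)=O`, differs from compound 3 by fluoro in place of methyl on an aromatic carbon. Going by the values given here, no measured step bears on this change, so no direction or size can be read from the data. Compound 4 is expected to sit near the limit as well, with an estimated step that the limit leaves unreadable from compound 3 to compound 4 carrying little weight. The estimate for compound 4 in this assay is 60000 nM, ranging from 15000 nM to 200000 nM.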

Compound 4, half-maximal inhibitory concentration: > 50000 nM
Compound 4 was reported as a limit; the forecaster's own chance of this, stated with the estimate: 75%; the middle value lies beyond the limit too.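

For the compounds shown here, compound 4 is also only a limit, so no step from compound 2 or compound 3 to compound 4 can be read: the limit of > 50000 nM in this assay, at which 4 of the 4 values shown sit.
The compounds shown leave open whether hydrogen, methyl or fluoro at this place differ at all.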